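Chloropyridine in Place of Cyanophenyl on the Shared Core

A few compounds are considered here, and "the series" means these few. Any claim that something is new, unique, unknown or untested is made for them only; others in the source may bear on it.

Measured in a functional assay on MCF7 cells (Homo sapiens) for cytotoxicity, read by CellTiter-Glo, with a stated time of 5 days; on this read-out higher numbers stand for weaker inhibition and lower numbers for stronger inhibition:
compound 2 `CC/C(=C(/c1ccc(/C=C/C(=O)O)cc1)c1ccc2[nH]cnc2c1)c1ccccc1` gives 1180 nM
compound 3 `CC/C(=C(/c1ccc(/C=C/C(=O)O)cc1)c1ccc2[nH]ncc2c1)c1cccc(C#N)c1` gives 100 nM
compound 1 `CC/C(=C(/c1ccc(/C=C/C(=O)O)cc1)c1ccc(O)nc1)c1ccccc1` is recorded as "not determined" (no result reported) and so has no result in this assay

Compound 3 holds the lowest number of the two that were obtained in this assay; compound 2, its nearest neighbour, sits well beyond the scatter above it, and compound 1 contributes no number at all. For the measured compounds named here, no two measured compounds differ in a single place, so no measured step is available to calibrate what a change at the double-bonded chain carbon bound to a double-bonded chain carbon and a saturated chain carbon does.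

Compound 4 `CC/C(=C(/c1ccc(/C=C/C(=O)O)cc1)c1ccc2[nH]ncc2c1)c1ccncc1Cl` is to be measured in this assay. Its difference from compound 3 is 3-chloropyridin-4-yl in place of 3-cyanophenyl on a double-bonded chain carbon bound to a double-bonded chain carbon and a saturated chain carbon. Going by the values given here, with no related step on record, the expectation for compound 4 in this assay is a step of small size, if any, leaning toward a slightly higher number rather than a lower one, and quite possibly none beyond the scatter. Compound 4 is therefore estimated at 200 nM, with a range from 60 nM to 700 nM. This estimate means a step of a 2.0-fold higher number from compound 3 to compound 4 (0.30 log units; within the scatter) is expected.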

Compound 4, half-maximal inhibitory concentration: 4 nM
The estimate for compound 4 lay 50-fold (1.70 log units) above the measured number; measured number below the stated range.
By their numbers in this assay, from the lowest: compound 4; then compound 3; then compound 2.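

In this assay, for the compounds shown here, putting 3-chloropyridin-4-yl in place of 3-cyanophenyl on a double-bonded chain carbon bound to a double-bonded chain carbon and a saturated chain carbon gives a 25-fold lower number from compound 3 to compound 4 (1.40 log units; beyond the scatter) and provides the first measured step at this position, showing that the read-out responds strongly to the group held there. The exchange happens in one place but changes several things together: the nitrile leaves, a chlorine enters, and the carbon-only aromatic ring gives way to a ring with a hetero atom, so the step can be assigned only to the whole exchange and not to any one of these features. No measurement bearing on the reason for this step is available, and its cause remains unassigned.

As far as these compounds go, whether the chlorine, the ring nitrogen or their combination carries the step remains open, and a 3-chlorophenyl group and an unsubstituted pyridin-4-yl group at this place would be the direct tests of that question. Also open, from the compounds shown here alone, is whether a bromine or a methyl group could take the place of the chlorine, and whether the same exchange would produce a comparable step on the core of compound 2.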